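Shortening the amide chain of compound 3

A few compounds are considered here, and "the series" means these few. Any claim that something is new, unique, unknown or untested is made for them only; others in the source may bear on it.

- compound 1 `CCOC(=O)c1sc2ncnc(Nc3ccc(F)cc3)c2c1C` gives 5250 nM
- compound 2 `Cc1c(C(N)=O)sc2ncnc(Nc3ccc(F)cc3OC(C)C)c12` gives 6080 nM
- compound 3 `COCCCNC(=O)c1sc2ncnc(Nc3ccc(F)cc3OC(C)C)c2c1C` gives 15300 nM

In a functional assay on MV4-11 cells (Homo sapiens) for inhibition, read by resazurin assay, with a stated time of 72 h (on this read-out lower numbers stand for stronger inhibition of growth and higher numbers for weaker inhibition of growth), compound 3 has the highest number of the three, beyond the scatter from both others. Compound 4 `CNC(=O)c1sc2ncnc(Nc3ccc(F)cc3OC(C)C)c2c1C` differs by hydrogen in place of 2-methoxyethyl on a saturated chain carbon bound to an amide-type nitrogen on a saturated chain carbon bound to an amide-type nitrogen, so 3-methoxypropyl becomes methyl. For the measured compounds named here, the only measured step bearing on this is a 2.5-fold higher number from compound 2 to compound 3 (0.40 log units; beyond the scatter) which is modest and puts 3-methoxypropyl in place of hydrogen on that nitrogen. Cutting the chain back to methyl is expected to undo most of that step, giving a modest move to a lower number. The expected change is a 2.2-fold lower number from compound 3 to compound 4 (0.34 log units; beyond the scatter) in this assay on this single precedent. For compound 4 the estimate is 7000 nM with 2800 nM to 17000 nM as the expected range.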

Compound 4, concentration for 50% growth inhibition: 5290 nM
Estimate against measurement, compound 4: 1.3-fold (0.12 log units) above; low and high end bracket the measured number.
By their numbers in this assay, from the lowest: compounds 1, 4 and 2 (each within the scatter of the next); then compound 3.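

In this assay, the cost of the 3-methoxypropyl chain on the amide nitrogen disappears when it is cut back to methyl: a 2.9-fold lower number from compound 3 to compound 4 (0.46 log units; beyond the scatter). Methyl and the amide hydrogen are not told apart, with a 1.1-fold lower number from compound 2 to compound 4 (0.06 log units; within the scatter), so on these compounds the higher number belongs to the longer chain rather than to any substitution on this nitrogen. Nothing available here accounts for this result.

Open, as far as these compounds go, is whether chain length or the ether oxygen carries the cost, which a plain butyl chain on this nitrogen would separate. From the compounds shown here alone, how a chain ending in an amine would behave here is also open.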